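The compounds below may be only part of what the source reports. "The series", "measured", "known", "first", "only" and "open" are said of these compounds alone.

Three measured compounds share one core and differ in a single group on an aromatic ring. Compound 1 `CC(O)(C(=O)Nc1ccc(S(=O)(=O)c2ccccc2)c(F)c1)C(F)(F)F` carries a fluoro there; in a functional assay (Cavia porcellus) with sulfonylurea receptors; K-ATP channels (Homo sapiens) as the target (on this read-out lower numbers stand for stronger inhibition and higher numbers for weaker inhibition), compound 1 gives 1800 nM. Compound 2 `CC(O)(C(=O)Nc1ccc(S(=O)(=O)c2ccccc2)c(C#N)c1)C(F)(F)F` carries a cyano, and in this assay compound 2 gives 3800 nM. Compound 3 `CC(O)(C(=O)Nc1ccc(S(=O)(=O)c2ccccc2)c(O)c1)C(F)(F)F` carries a hydroxy, and in this assay compound 3 gives 430 nM, the lowest of the three numbers: there is a 4.2-fold lower number from compound 1 to compound 3 (0.62 log units; beyond the scatter) and an 8.8-fold lower number from compound 2 to compound 3 (0.95 log units; beyond the scatter), while a 2.1-fold higher number from compound 1 to compound 2 (0.32 log units; beyond the scatter). Compound 4 `COc1cc(NC(=O)C(C)(O)C(F)(F)F)ccc1S(=O)(=O)c1ccccc1` is made from compound 3 by methyl in place of hydrogen on an oxygen on an aromatic ring. For the measured compounds named here, no measured step changes the hydroxy itself, so nothing directly tells what methylating it does. The two steps that lead into the hydroxy, from compound 1 and from compound 2, both lowered the number well beyond the scatter, which makes the hydroxy the one group that stands out among these three. Capping it with a methyl removes the group exactly as it was measured, and part of its advantage is therefore expected to be lost, so a 3.5-fold higher number from compound 3 to compound 4 (0.54 log units; beyond the scatter) is expected. Compound 4 is estimated at 1500 nM, with a range from 500 nM to 4500 nM.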

Compound 4, half-maximal inhibitory concentration: 5900 nM
Compound 4: the middle estimate sits 3.9-fold (0.59 log units) below what was measured; the measured number lies above the stated range.
By their numbers in this assay, from the lowest: compound 3; then compound 1; then compounds 2 and 4 (each within the scatter of the next).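

Adding one methyl to the hydroxy in this assay gives a 14-fold higher number from compound 3 to compound 4 (1.14 log units; beyond the scatter), the only step in this set graded as large, so the advantage of compound 3 is not just reduced but lost. The methoxy does not retain that advantage: a 1.6-fold higher number from compound 2 to compound 4 (0.19 log units; within the scatter) leaves it level with the cyano group, while a 3.3-fold higher number from compound 1 to compound 4 (0.52 log units; beyond the scatter) shows a weaker result than with the fluoro group. Since the methoxy still has an oxygen on the aromatic ring, the low number of compound 3 cannot come from having an oxygen there alone; it appears only with the hydroxy intact, and no accompanying measurement explains why this is so.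

The compounds shown leave open whether other groups at this position, such as an amine or a carboxylic acid, could match or improve on the hydroxy. They also leave open whether a longer chain on the oxygen, such as ethoxy, would change the number further or stay close to the methoxy, and whether the same hydroxy-to-methoxy change would have a similar effect on a different core.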